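Bromo in place of methoxy: expected effect of one swap

This account rests on a few compounds, and the source may have more. Where it says the series, first, only, none or still open, it means among the compounds named here.

Of the compounds shown here, three have been measured in a functional assay on A549 cells (Homo sapiens) for inhibition, tested at 100 uM; a lower number here means a weaker effect, a higher number a stronger effect of the compound at the concentration tested. Compound 1 `COc1ccc2c(c1)c(-c1cc(C(F)(F)F)c(C#N)c(-c3cn(S(=O)(=O)c4ccc(C)cc4)c4ccc(OC)cc34)n1)cn2S(=O)(=O)c1ccc(C)cc1` gives 17.7%. Compound 2 `COc1ccc2c(c1)c(-c1cc(C(F)(F)F)ccn1)cn2S(=O)(=O)c1ccc(C)cc1` gives 35.9%. Compound 3 `Cc1ccc(S(=O)(=O)n2cc(-c3cc(C(F)(F)F)c(C#N)c(-c4cn(S(=O)(=O)c5ccc(C)cc5)c5cc(Br)ccc45)n3)c3ccc(Br)cc32)cc1` gives 48.1%. On these three numbers compound 2 stands second highest; compound 3 lies higher by an amount beyond the scatter, and compound 1 lies lower by an amount beyond the scatter.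

Compound 4 `Cc1ccc(S(=O)(=O)n2cc(-c3cc(C(F)(F)F)ccn3)c3cc(Br)ccc32)cc1` has not yet been measured. It differs from compound 2 in one place: bromo in place of methoxy on an aromatic carbon. Among the measured compounds shown here, no pair of measured compounds differs in exactly one place, so no measured single step is available as a direct guide. Compound 1 and compound 3 differ from each other in more than one place, yet their two values show the bromo-bearing compound 3 at a higher inhibition than the methoxy-bearing compound 1, with the gap beyond the scatter.

For this assay an increase is expected from compound 2 to compound 4, moderate in size and somewhat beyond the scatter, read with caution since the comparison of compound 1 with compound 3 involves more than one change. The expected step is a number 9.1 percentage points higher from compound 2 to compound 4 (within the scatter). Compound 4 is estimated at 45%, with a range from 28% to 62%.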

Compound 4, a percentage reported as inhibition, at one concentration (the size of the read-out at that concentration, not a potency): 98%
Compound 4: middle estimate off by 53 percentage points, on the low side, outside the stated range (above it).
By their numbers in this assay, from the lowest: compound 1; then compound 2; then compound 3; then compound 4.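

In this assay, among the compounds shown here, the exchange of methoxy for bromo on this aromatic carbon gives the only single-change reading so far: a number 62.1 percentage points higher from compound 2 to compound 4 (beyond the scatter), a large step. The earlier compounds shown here included no pair differing in one place, so they could not show that this position alone can move the read-out so strongly; with the rest of compound 2 left unchanged, this one swap takes compound 4 to 98% at the single concentration tested. No measurement at hand accounts for the size of this step.

It remains open whether the gain is particular to bromo or would also appear with chloro, methyl or an amine on the same carbon, since the series shown holds only methoxy and bromo at this kind of position. Also open, on these data alone, are whether the swap has a similar effect on a core carrying a nitrile, and how compound 4 would rank by potency, as a read-out at one concentration gives no concentration-response information.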